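The compounds below may be only part of what the source reports. "The series", "measured", "known", "first", "only" and "open" are said of these compounds alone.

Measured so far:
- compound 1 `CCOC1c2cc(OCc3cc(C)cc(C)c3)c(OCc3cc(C)cc(C)c3)cc2CCN1C(=O)OC(C)(C)C`: > 20000 nM
- compound 2 `CCC[C@@H]1C[C@@H](O)/C=C\C(CC)[C@H]2c3cc(OCc4ccccc4)c(OCc4ccccc4)cc3CCN12`: "not determined" (no result reported)

In a functional assay on MCF7 cells (Homo sapiens) for inhibition, read by MTT assay, with a stated time of 24 h (a higher number here means a weaker inhibitor, a lower number a stronger inhibitor), compound 1 gives > 20000 nM, which is a limit of the assay and not a number. Among the measured compounds shown here, compound 2 has no result, so the series offers no measured step. Compound 3 `C/C=C/C(=O)CC1c2cc(OCc3cc(C)cc(C)c3)c(OCc3cc(C)cc(C)c3)cc2CCN1C(=O)OC(C)(C)C` carries ((prop-1-en-1-yl)carbonyl)methyl in place of ethoxy on a saturated ring carbon of the core of compound 1 (((prop-1-en-1-yl)carbonyl)methyl in place of ethoxy on a saturated ring carbon). A modest step towards stronger inhibition in this assay is expected, with a real chance that compound 3 also ends at the limit, and the expected step is an at least 1.3-fold lower number from compound 1 to compound 3 (0.12 log units; that floor lies within the scatter). The estimate for compound 3 is 15000 nM, with an expected range of 4000 nM to 40000 nM.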

Compound 3, half-maximal inhibitory concentration: > 20000 nM
Compound 3 ended at the assay's limit; the forecaster's own chance of this, stated with the estimate: 45%; at least 1.3-fold (0.12 log units) between middle value and limit.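

Compound 3 gives > 20000 nM in this assay, a limit and not a number. Compound 1 gives > 20000 nM, also a limit, so no step from compound 1 to compound 3 can be read: the limit of > 20000 nM in this assay, at which 2 of the 3 values shown sit.

The compounds shown leave open whether ((prop-1-en-1-yl)carbonyl)methyl in place of ethoxy changes inhibition at all.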